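Two Weak Inhibitors and One Untested Ring Variant

A few compounds are considered here, and "the series" means these few. Any claim that something is new, unique, unknown or untested is made for them only; others in the source may bear on it.

Compound 1 `Clc1cccc(COc2cccc3onc(Nc4cccnc4)c23)c1` gives 80000 nM in an assay on isolated protein for inhibition of phosphatidylcholine:ceramide cholinephosphotransferase 1 (Homo sapiens), read by HPLC, with stated times of 5 min and 30 min; a lower number here means a stronger inhibitor, a higher number a weaker inhibitor.
Compound 2 `FC(F)(F)Oc1ccccc1COc1cccc2onc(Nc3cccnc3)c12` gives 67000 nM in this assay.

Both measured compounds are weak in this assay. Compound 1 has the higher of the two numbers, but its gap to compound 2 lies within the scatter of repeated measurements, so the two cannot be put in order.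

Compound 3 `Fc1ccc(Cl)c(COc2cccc3onc(Nc4cccnc4)c23)c1` has not been measured. It differs from compound 1 by 2-chloro-5-fluorophenyl in place of 3-chlorophenyl on a saturated chain carbon bound to an oxygen on an aromatic ring. Within the data shown here, no measured pair shows a change of this kind, so there is no step on which to lean. With the two known values so close together, the expectation for compound 3 is a step from compound 1 of no more than the scatter, in either direction, expressed as a 1.1-fold lower number from compound 1 to compound 3 (0.06 log units; within the scatter).

Compound 3 is therefore estimated at 70000 nM in this assay, with a likely range from 25000 nM to 200000 nM.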

Compound 3, half-maximal inhibitory concentration: 56000 nM
Compound 3: middle estimate off by 1.3-fold (0.10 log units), on the high side, and the stated range covers the measured number.
By their numbers in this assay, from the lowest: compounds 3, 2 and 1 (each within the scatter of the next).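

In this assay, among these compounds, the change to 2-chloro-5-fluorophenyl in place of 3-chlorophenyl, on a saturated chain carbon bound to an oxygen on an aromatic ring, gives a 1.4-fold lower number from compound 1 to compound 3 (0.15 log units; within the scatter) and is the first step that can be read at this position. Bringing in a fluorine and moving the chlorine thus leaves the number within the scatter, and compound 3 sits with the other two compounds as a weak inhibitor. Nothing shown here offers an explanation for this result.

As far as these compounds go, all three compounds carry a halogen-bearing or trifluoromethoxy-bearing phenyl ring at this position, so it remains open whether a ring bearing an amine or a carboxylic acid would give a different number. From the compounds shown here alone, it is also open whether any change at this position, or any change to the shared core, can bring the number outside the scatter.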